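Permeability notes: towards the 3-(trifluoromethyl)phenyl analogue, compound 4

This account rests on a few compounds, and the source may have more. Where it says the series, first, only, none or still open, it means among the compounds named here.

The series shares one core and varies the aryl group on the saturated chain carbon bound to an aromatic nitrogen and a saturated chain carbon. In an ADME assay for permeability (on this read-out lower numbers stand for lower permeability and higher numbers for higher permeability), compound 1 `CNC(=O)c1cc(C(=O)N[C@H]2CC[C@H](O)CC2)n([C@@H](C)c2cccc(Cl)c2)n1` gives 235 nm/s, compound 2 `CNC(=O)c1cc(C(=O)N[C@H]2CC[C@H](O)CC2)n([C@@H](C)c2cccc(C)c2)n1` gives 110 nm/s, and compound 3 `CNC(=O)c1cc(C(=O)N[C@H]2CC[C@H](O)CC2)n([C@@H](C)c2ccccc2Cl)n1` gives 100 nm/s. Compound 3 sits at the bottom of the three numbers, but its gap to compound 2 is within the scatter, so only compound 1 stands clearly apart from it.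

Compound 4 `CNC(=O)c1cc(C(=O)N[C@H]2CC[C@H](O)CC2)n([C@@H](C)c2cccc(C(F)(F)F)c2)n1` differs from compound 3 by 3-(trifluoromethyl)phenyl in place of 2-chlorophenyl on a saturated chain carbon bound to an aromatic nitrogen and a saturated chain carbon. Among the compounds with values here, two measured steps bear on this. Moving the chloro from the 3-position to the 2-position gave a 2.4-fold lower number from compound 1 to compound 3 (0.37 log units; beyond the scatter), so returning to a 3-substituted phenyl is expected to undo roughly that much. Within the data shown here, exchanging chloro for methyl at the 3-position gave a 2.1-fold lower number from compound 1 to compound 2 (0.33 log units; beyond the scatter); no measured step covers chloro against trifluoromethyl, so that part stays open. On balance a rise back towards the level of compound 1 is expected, estimated as a 2.1-fold higher number from compound 3 to compound 4 (0.32 log units; beyond the scatter), with the open substituent question widening the range. For compound 4 the estimate in this assay is 210 nm/s, with a range from 110 nm/s to 400 nm/s.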

Compound 4, apparent permeability in the ADME assay: 280 nm/s
For compound 4 the middle estimate is 1.3-fold (0.12 log units) below the measured one; low and high end bracket the measured number.
By their numbers in the ADME assay, from the lowest: compounds 3 and 2 (each within the scatter of the next); then compounds 1 and 4 (each within the scatter of the next).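

In the ADME assay trifluoromethyl on the aromatic carbon matches chloro (a 1.2-fold higher number from compound 1 to compound 4 (0.08 log units; within the scatter)) and separates from methyl (a 2.5-fold higher number from compound 2 to compound 4 (0.41 log units; beyond the scatter)), and the full change of aryl group gives a clear step (a 2.8-fold higher number from compound 3 to compound 4 (0.45 log units; beyond the scatter)), so 3-(trifluoromethyl)phenyl joins 3-chlorophenyl at the upper level, while compound 2, with its 3-methylphenyl, stays within the scatter of compound 3 and goes against any reading that the place on the ring alone sets the number. In a physicochemical assay for solubility, measured as kinetic solubility (on this read-out lower numbers stand for lower solubility and higher numbers for higher solubility), compound 3 gives >= 182 ug/mL, which is a limit of the assay. In the physicochemical assay compound 4 gives 7 ug/mL, and the same change of aryl group now reads as a large step in the opposite direction (an at least 26-fold lower number from compound 3 to compound 4 (1.41 log units; beyond the scatter)).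

As far as these compounds go, the two solubility values shown do not separate the change of group from the change of place on the ring, so how much of that step belongs to trifluoromethyl itself stays open. Also open, from the compounds shown here alone, is whether a phenyl carrying an amine or a carboxylic acid would hold the upper level in the ADME assay while giving a different reading in the physicochemical assay.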